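The source may report more compounds than this note shows. Statements on the series, on what has been measured and on what is new or still open speak of the compounds shown alone.

Measured compounds:
compound 1 `COc1cccc(OCc2nc3c(c(=O)n(C)c(=O)n3C)n2C)c1` gives 1960 nM in an in vitro assay on cells for inhibition of Amine oxidase [flavin-containing] B (Homo sapiens), read by coupled enzyme assay, with a stated time of 20 min; on this read-out lower numbers stand for stronger inhibition and higher numbers for weaker inhibition
compound 2 `Cn1c(=O)c2c(nc(CCSc3ccc(Cl)cc3)n2C)n(C)c1=O` gives 7790 nM
compound 3 `Cn1c(=O)c2c(nc(CCSc3cccc(Cl)c3)n2C)n(C)c1=O` gives 5670 nM

Compound 1 stands lowest of the three numbers in this assay; compound 3 is nearest and compound 2 furthest, both gaps beyond the scatter. Compound 4 `Cn1c(=O)c2c(nc(COc3ccc(Br)cc3)n2C)n(C)c1=O` differs from compound 1 by 4-bromophenyl in place of 3-methoxyphenyl on an oxygen on a saturated carbon. Going by the values given here, the only measured step, a 1.4-fold lower number from compound 2 to compound 3 (0.14 log units; within the scatter), moves the chlorine on a chlorophenyl attached through sulfur and stays within the scatter; it does not cover an exchange of methoxy for bromine on the oxygen-linked phenyl, so no step bears directly on this change. The expectation is therefore a shift of about a 1.3-fold higher number from compound 1 to compound 4 (0.12 log units; within the scatter), not clearly beyond the scatter. Compound 4 is estimated at 2600 nM in this assay, with a range of 900 nM to 7500 nM.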

Compound 4, half-maximal inhibitory concentration: 189 nM
Compound 4: middle estimate off by 14-fold (1.14 log units), on the high side, outside the stated range (below it).
By their numbers in this assay, from the lowest: compound 4; then compound 1; then compounds 3 and 2 (each within the scatter of the next).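

In this assay, going by these compounds alone, the aryl group on an oxygen on a saturated carbon proves a sensitive place: 4-bromophenyl in place of 3-methoxyphenyl gives a 10-fold lower number from compound 1 to compound 4 (1.02 log units; beyond the scatter) as a large step, whereas the only earlier step, a 1.4-fold lower number from compound 2 to compound 3 (0.14 log units; within the scatter) on a sulfur-linked aryl group, stayed within the scatter. The change alters both the substituent and its location on the phenyl, so neither alone can be credited. Nothing available accounts for the size of this step.

Open, from the compounds shown here alone, is whether 3-bromophenyl or 4-methoxyphenyl would separate those two contributions. Also open, going by these compounds, is how an amine or a carboxylic acid on the phenyl would read here.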